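From Methoxy to Cyano on Compound 2

The source may hold more compounds than are shown below. What is called first, only, known or untested is meant among the compounds shown, and "the series" means these compounds.

In a physicochemical assay for solubility, read by HPLC, in phosphate buffer, at pH 7.4 (on this read-out lower numbers stand for lower solubility and higher numbers for higher solubility), compound 2 `COc1ccc(Nc2nc(NCCCO)c3ccccc3n2)cc1` gives 95.6 ug/mL, the highest of three numbers. Compound 1 `COc1ccc(Nc2nc(NC3CCCC3)c3ccccc3n2)cc1` gives 10.4 ug/mL, and compound 3 `CNc1nc(Nc2ccc(OC)cc2)nc2ccccc12` gives 6.61 ug/mL. Compound 4 `N#Cc1ccc(Nc2nc(NCCCO)c3ccccc3n2)cc1` has cyano in place of methoxy on an aromatic carbon. Among the measured compounds shown here, no measured step touches that carbon. All three change the group on a different nitrogen: a 9.2-fold higher number from compound 1 to compound 2 (0.96 log units; beyond the scatter), a 14-fold lower number from compound 2 to compound 3 (1.16 log units; beyond the scatter) and a 1.6-fold lower number from compound 1 to compound 3 (0.20 log units; within the scatter). They show only how far this assay can move in this small set, so they guide the size of the new step loosely. With compound 2 at the top at 95.6 ug/mL, a modest fall is expected, an estimated 2.4-fold lower number from compound 2 to compound 4 (0.38 log units; beyond the scatter). Compound 4 is estimated at 40 ug/mL, with an expected range of 10 ug/mL to 120 ug/mL.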

Compound 4, solubility: 7.52 ug/mL
The estimate for compound 4 lay 5.3-fold (0.73 log units) above the measured number; the whole stated range lies above it.
By their numbers in this assay, from the lowest: compounds 3, 4 and 1 (each within the scatter of the next); then compound 2.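

The aromatic carbon para to a large group matters in its own right: 4-methoxyphenyl to 4-cyanophenyl gives a 13-fold lower number from compound 2 to compound 4 (1.10 log units; beyond the scatter), so the number depends on more than the group on the other nitrogen. Methoxy and cyano match in heavy atoms and in hydrogen-bond donors and acceptors, so these counts do not foretell the step. No measurement here gives a reason for this fall.

Going by these compounds, whether an amine or a carboxylic acid on this carbon would give a higher number stays open. So does whether the same change would give a step of this size with cyclopentyl or methyl on the other nitrogen.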